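Swapping an Ethoxy Group for a Bromophenyl Ethenyl Chain

The source may report more compounds than this note shows. Statements on the series, on what has been measured and on what is new or still open speak of the compounds shown alone.

Three compounds have been measured in a functional assay on MCF7 cells (Homo sapiens) for cytotoxicity, read by MTT assay, with a stated time of 72 h; on this read-out higher numbers stand for weaker inhibition and lower numbers for stronger inhibition:
compound 1 `O=C(CSC(=S)N[C@H]1CCOC1=O)Nc1ccc(F)cc1` gives 5830 nM
compound 2 `CCOC(=O)c1ccc(NC(=O)CSC(=S)N[C@H]2CCOC2=O)cc1` gives 60300 nM
compound 3 `CCCCc1ccc(NC(=O)CSC(=S)N[C@H]2CCOC2=O)cc1` gives 40200 nM

Compound 2 has the highest number of the three. Its value and that of compound 3 lie within the scatter of each other (a 1.5-fold lower number from compound 2 to compound 3 (0.18 log units; within the scatter)), so no order between them can be claimed. The gap to compound 1 is beyond the scatter: a 10-fold higher number from compound 1 to compound 2 (1.01 log units; beyond the scatter), and the related change a 6.9-fold higher number from compound 1 to compound 3 (0.84 log units; beyond the scatter) points the same way.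

Compound 4 `O=C(CSC(=S)N[C@H]1CCOC1=O)Nc1ccc(C(=O)/C=C/c2ccc(Br)cc2)cc1` keeps the core of compound 2 and alters only the group on a carbonyl carbon whose other neighbour is an aromatic carbon: 2-(4-bromophenyl)ethenyl in place of ethoxy on a carbonyl carbon. For the measured compounds named here, none of the measured steps involves a replacement of this kind; the steps seen so far only exchange the group sitting on an aromatic carbon. They show that changes at that end of the molecule can shift the number by a large or a modest amount, but they give no direction for a change at the carbonyl carbon. With that weak guide, a somewhat lower number is expected for compound 4, a 3.0-fold lower number from compound 2 to compound 4 (0.48 log units; beyond the scatter), with wide uncertainty in both directions. The estimate for compound 4 in this assay is 20000 nM, ranging from 4000 nM to 100000 nM.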

Compound 4, half-maximal inhibitory concentration: 18700 nM
Beside the measured number, compound 4's estimate is 1.1-fold (0.03 log units) above it, within the range that was stated.
By their numbers in this assay, from the lowest: compound 1; then compound 4; then compounds 3 and 2 (each within the scatter of the next).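

In this assay, for the compounds shown here, the carbonyl carbon whose other neighbour is an aromatic carbon proves to be a place where a change can move the number, and here the step is a 3.2-fold lower number from compound 2 to compound 4 (0.51 log units; beyond the scatter); the earlier steps only exchanged groups on an aromatic carbon. Ethoxy leaves and 2-(4-bromophenyl)ethenyl enters, adding an aromatic ring, a bromine and a double bond outside aromatic rings, and this much larger group is compatible with a stronger result than ethoxy in this pair. No measurement of any other kind is available to explain this shift.

This single step cannot show how much of the shift belongs to the bromine, the double bond or the aromatic ring, and a 2-phenylethenyl group without bromine or a 2-(4-bromophenyl)ethyl chain on the same carbonyl carbon would help to separate these parts. It also leaves open how a different kind of group on that carbon, such as an amine or the hydroxyl of a carboxylic acid, would move the number, and in which direction.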